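This account rests on a few compounds, and the source may have more. Where it says the series, first, only, none or still open, it means among the compounds named here.

Three related compounds have been tested in an ADME assay on cells (Homo sapiens) for activation; a higher number here means that more compound is tolerated, a lower number that less compound is tolerated. Compound 1 `COc1ccc2c(OCC[C@@H]3NC(=O)N(C)CCCC/C=C\[C@@H]4C[C@@]4(C(=O)NS(=O)(=O)C4(C)CC4)NC3=O)cc(-c3nc(C(C)C)cs3)nc2c1F` gives 57100 nM. For the measured compounds named here, compound 2 `COc1ccc2c(OCC[C@@H]3NC(=O)N(C)CCCC/C=C\[C@@H]4C[C@@]4(C(=O)NS(=O)(=O)C4(C)CC4)NC3=O)cc(-c3nc(C(C)C)cs3)nc2c1` carries hydrogen in place of fluoro on an aromatic carbon and gives 6500 nM, and the step of an 8.8-fold lower number from compound 1 to compound 2 (0.94 log units; beyond the scatter) is the only single-change comparison available among the measured compounds. Compound 3 `COc1ccc2c(OCC[C@@H]3NC(=O)N(C)CCCC/C=C\[C@@H]4C[C@@]4(C(=O)NS(=O)(=O)C4(F)CC4)NC3=O)cc(-c3nc(C(C)C)cs3)nc2c1Cl` gives 51400 nM, the second highest of the three numbers: it lies within the scatter of compound 1 and clearly apart from compound 2.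

The next compound, compound 4 `COc1ccc2c(OCC[C@@H]3NC(=O)N(C)CCCC/C=C\[C@@H]4C[C@@]4(C(=O)NS(=O)(=O)N(C)C)NC3=O)cc(-c3nc(C(C)C)cs3)nc2c1Cl`, differs from compound 3 at the sulfonyl sulfur: dimethylamino in place of 1-fluorocyclopropyl on a sulfonyl sulfur. Going by the values given here, no measured step touches this part of the shared core. Among the compounds with values here, the one step measured, an 8.8-fold lower number from compound 1 to compound 2 (0.94 log units; beyond the scatter), concerns a different place, a substituent on an aromatic carbon, and says nothing about exchanging groups on the sulfonyl sulfur. There is thus no basis for expecting a shift in either direction, and the step from compound 3 to compound 4 is expected to be none beyond the scatter, a 1.1-fold lower number from compound 3 to compound 4 (0.06 log units; within the scatter). Compound 4 is accordingly estimated at 45000 nM, with a likely range from 15000 nM to 120000 nM.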

Compound 4, half-maximal cytotoxic concentration: 47800 nM
Beside the measured number, compound 4's estimate is 1.1-fold (0.03 log units) below it, and the stated range covers the measured number.
By their numbers in this assay, from the lowest: compound 2; then compounds 4, 3 and 1 (each within the scatter of the next).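

In this assay, putting dimethylamino in place of 1-fluorocyclopropyl on a sulfonyl sulfur gives a 1.1-fold lower number from compound 3 to compound 4 (0.03 log units; within the scatter), so the two compounds cannot be told apart. For the compounds shown here, this is the first single-change reading at this place, since the only earlier step concerned a substituent on an aromatic carbon, and it shows that a ring of carbon carrying fluorine can give way to an open group carrying nitrogen with no change beyond the scatter, at least for this pair. Nothing shown here gives a measured property of either group that could account for this outcome.

One pair cannot show whether this place is generally insensitive to change, and a group such as a primary amine, a longer alkyl chain or a phenyl ring on the sulfonyl sulfur could still move the number in either direction. Also open, from the compounds shown here alone, is whether the same exchange would give a similar result with hydrogen or fluoro on the aromatic carbon that separates compound 1 from compound 2, where the number did shift beyond the scatter.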